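A few compounds are considered here, and "the series" means these few. Any claim that something is new, unique, unknown or untested is made for them only; others in the source may bear on it.

Working notes on a benzoxazole amide series.

Compound 1 `Cc1cc(-c2nc3cc(Cl)ccc3o2)ccc1NC(=O)CN1CCN(CCCN(C)C)CC1` carries a piperazine acetamide side chain; in a functional assay on HT-29 cells (Homo sapiens) for cytotoxicity, read by MTT assay, with a stated time of 24 h (a higher number here means a weaker inhibitor, a lower number a stronger inhibitor), compound 1 gives 9150 nM. Compound 3 `Cc1ccc2oc(-c3ccc(NC(=O)CN4CCN(CCCN(C)C)CC4)c(C)c3)nc2c1` keeps that side chain and differs from compound 1 by a single change, (methyl in place of chloro on an aromatic carbon); in this assay compound 3 gives 12700 nM. The step of a 1.4-fold higher number from compound 1 to compound 3 (0.14 log units; within the scatter) is small, so on this core the two substituents read alike in this assay.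

Compound 2 `Cc1cc(-c2nc3cc(Cl)ccc3o2)ccc1NC(=O)CCl` carries a chloroacetamide in place of the piperazine acetamide. In this assay compound 2 gives only a limit, > 100000 nM, and no number. How the core of compound 2 differs from that of compound 1 is not broken down here.

Compound 4 `Cc1ccc2oc(-c3ccc(NC(=O)CCl)c(C)c3)nc2c1` is not yet measured. It relates to compound 2 by methyl in place of chloro on an aromatic carbon, the same change as that from compound 1 to compound 3, made on the same place of the core. Given that the measured step of a 1.4-fold higher number from compound 1 to compound 3 (0.14 log units; within the scatter) is within the scatter, and given the limit of > 100000 nM in this assay, at which 1 of the 3 values shown sits, for compound 2, compound 4 is expected to sit in the same region, with an expected step that the limit leaves unreadable from compound 2 to compound 4. The estimate for compound 4 in this assay is 150000 nM, between 40000 nM and 500000 nM, most likely reported again as a limit.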

Compound 4, half-maximal inhibitory concentration: 13800 nM
Compound 4: the middle estimate sits 11-fold (1.04 log units) above what was measured; measured number outside the range, below it.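

In this assay the same change, methyl in place of chloro on an aromatic carbon, gives an at least 7.2-fold lower number from compound 2 to compound 4 (0.86 log units; beyond the scatter), so on the chloroacetamide it does not read as it does on the piperazine acetamide, and the two steps differ: the same change on two cores in this assay, a 1.4-fold higher number (0.14 log units; within the scatter) from compound 1 to compound 3 and an at least 7.2-fold lower number (0.86 log units; beyond the scatter) from compound 2 to compound 4, at least 10-fold (1.00 log units) apart, beyond the scatter of two such steps

The step on the chloroacetamide is only a minimum, since compound 2 rests on a limit of the assay and not on a number: the limit of > 100000 nM in this assay, at which 1 of the 4 values shown sits.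

The result shows that the step seen on one side chain could not be carried over to the other here, but two pairs give no rule for the series and do not show why the steps differ.

Open, going by these compounds, is whether a simple dimethylamino acetamide or a longer chloroalkyl amide chain would follow the pair of compound 1 and compound 3 or the pair of compound 2 and compound 4. Also open, on these data alone, is how fluoro or methoxy in the same place on the core would read on either side chain.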